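A few compounds are considered here, and "the series" means these few. Any claim that something is new, unique, unknown or untested is made for them only; others in the source may bear on it.

Measured compounds in this series:
- compound 1 `CCCCCCCCNC(=O)[C@@H](NC(=O)c1ccccc1)[C@@H](C)O`: 136000 nM
- compound 2 `CCCCCCCCCCCCNC(=O)[C@@H](NC(=O)c1ccccc1)[C@@H](C)O`: a limit, > 400000 nM
- compound 3 `CCCCCCCCCCCCNC(=O)[C@@H](NC(=O)c1cccs1)[C@@H](C)O`: 30100 nM

In a functional assay on HepG2 cells (Homo sapiens) for cytotoxicity, read by MTT assay, with a stated time of 48 h (a higher number here means a weaker inhibitor, a lower number a stronger inhibitor), compound 1 gives 136000 nM. For compound 2 only a limit is recorded, > 400000 nM; compound 2 therefore sits at the limit of > 400000 nM in this assay, at which 1 of the 3 values shown sits, and no number is known for it. Compound 3 gives 30100 nM in this assay.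

Compound 4 `CCCCCCCCCCCCCCNC(=O)[C@@H](NC(=O)c1ccccc1)[C@@H](C)O` differs from compound 2 by ethyl in place of hydrogen on a saturated chain carbon, ten or more bonds along the chain from an amide-type nitrogen, that is, a further lengthening of the same chain. For the measured compounds named here, one measured step bears on it: lengthening this chain by butyl gave an at least 2.9-fold higher number from compound 1 to compound 2 (0.46 log units; beyond the scatter), carrying compound 2 out to the limit. The step of an at least 13-fold lower number from compound 2 to compound 3 (1.12 log units; beyond the scatter) concerns the aryl part and does not bear on this change. Lengthening the chain further is thus expected to give no lower number, and most probably again only a limit.

Compound 4 is estimated at 450000 nM, with a range of 200000 nM to 1200000 nM. The step this estimate implies is a step that the limit leaves unreadable from compound 2 to compound 4, expected to lie within the scatter, with the value most likely reported as a limit.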

Compound 4, half-maximal inhibitory concentration: 54200 nM
The estimate for compound 4 lay 8.3-fold (0.92 log units) above the measured number; the measured number lies below the stated range.
By their numbers in this assay, from the lowest: compounds 3 and 4 (each within the scatter of the next); then compound 1. At a limit, above all of these: compound 2.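

In this assay, lengthening the chain at this position does not move the number in one direction: an at least 2.9-fold higher number from compound 1 to compound 2 (0.46 log units; beyond the scatter) is followed by an at least 7.3-fold lower number from compound 2 to compound 4 (0.86 log units; beyond the scatter). The further ethyl thus reverses the earlier change, and compound 4 also ends up on the other side of compound 1, with a 2.5-fold lower number from compound 1 to compound 4 (0.40 log units; beyond the scatter), so compound 2 goes against any steady rise or fall with chain length across these three compounds. The reversal rests on a limit and not on a number for compound 2: the limit of > 400000 nM in this assay, at which 1 of the 4 values shown sits.

On these data alone, how high compound 2 truly lies, and so how sharp this turn is, stays open. Also open, as far as these compounds go, are whether a longer chain than that of compound 4 keeps the lower number, and whether thiophen-2-yl in place of phenyl on the carbonyl carbon has the same effect on the chain of compound 4.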